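Urea series: bicyclic replacement for the pyridin-2-yl group

The source may report more compounds than this note shows. Statements on the series, on what has been measured and on what is new or still open speak of the compounds shown alone.

Compound 1 `CC(C)n1cnnc1-c1cccc(NC(=O)Nc2ccccn2)n1` gives 1090 nM in an assay on isolated protein for inhibition of mitogen-activated protein kinase kinase kinase 6 (Homo sapiens) (a higher number here means a weaker inhibitor, a lower number a stronger inhibitor), the lowest number of the three measured. Compound 2 `CC(C)n1cnnc1-c1cccc(NC(=O)Nc2ccc(-c3ccn(C)n3)cn2)n1` gives 2780 nM in this assay, and compound 3 `CC(C)n1cnnc1-c1cccc(NC(=O)Nc2ccc3ccccc3n2)n1` gives 2340 nM; both numbers lie beyond the scatter above that of compound 1. Compound 4 `CC(C)n1cnnc1-c1cccc(NC(=O)Nc2ncc3[nH]cnc3n2)n1` carries a group of 9 heavy atoms (5 carbon, 4 nitrogen; one five-membered aromatic ring with 2 hetero atoms, one six-membered aromatic ring with 2 hetero atoms) in place of a group of 6 heavy atoms (5 carbon, 1 nitrogen; one six-membered aromatic ring with 1 hetero atom), on an amide-type nitrogen. Going by the values given here, no measured step matches this change. Among the compounds with values here, the nearest precedent is the attachment of a further ring to the pyridin-2-yl group, a 2.6-fold higher number from compound 1 to compound 2 (0.41 log units; beyond the scatter), a modest loss; compound 3, with a larger ring system in place of pyridin-2-yl, also shows a higher number than compound 1. Both enlargements cost potency, so a modest weakening is expected, a 2.0-fold higher number from compound 1 to compound 4 (0.30 log units; within the scatter). Compound 4 is estimated at 2200 nM in this assay, within 700 nM to 7000 nM.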

Compound 4, half-maximal inhibitory concentration: 742 nM
Compound 4: middle estimate off by 3.0-fold (0.47 log units), on the high side, within the range that was stated.
By their numbers in this assay, from the lowest: compounds 4 and 1 (each within the scatter of the next); then compounds 3 and 2 (each within the scatter of the next).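

At the amide-type nitrogen, the larger group of compound 4 replaces pyridin-2-yl with a 1.5-fold lower number from compound 1 to compound 4 (0.17 log units; within the scatter), so in this assay this change shows no difference from compound 1 beyond the scatter. Size alone therefore does not set the outcome here: a 2.6-fold higher number from compound 1 to compound 2 (0.41 log units; beyond the scatter), and compound 3 also lies beyond the scatter above compound 1, whereas compound 4 does not follow them. Nothing measured here accounts for this contrast.

Open, as far as these compounds go, is whether the donor counted in the entering group matters, which a methyl group in place of the hydrogen on its five-membered ring would test. Also open, from the compounds shown here alone, is how an amine or a carboxylic acid on that bicyclic group would read in this assay.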